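Selenocyanate chain shortening in the quinazoline series

The compounds below may be only part of what the source reports. "The series", "measured", "known", "first", "only" and "open" are said of these compounds alone.

Three compounds of the series have been run in a functional assay on RKO cells (Homo sapiens) for inhibition, read by MTT assay, with a stated time of 48 h; a lower number here means a stronger inhibitor, a higher number a weaker inhibitor. Compound 1 `Cc1nc(N(C)c2ccc([Se]C#N)c(Cl)c2)c2ccccc2n1` gives 11 nM and compound 3 `CN(c1ccc([Se]C#N)cc1)c1nc(C2CC2)nc2ccccc12` gives 51 nM. Compound 2 `COc1ccc(N(C)c2nc(C)nc3ccccc23)cc1C(=O)OCCCCC[Se]C#N` stands at the high end of the three measured numbers with 356 nM; its nearest neighbour on the numbers is compound 3, and the gap to it, as to compound 1, is beyond the scatter of repeated runs in this assay.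

Compound 4 `COc1ccc(N(C)c2nc(C)nc3ccccc23)cc1C(=O)OCCCC[Se]C#N` has not yet been measured. It differs from compound 2 in one place: a group of 3 heavy atoms (1 carbon, 1 nitrogen, 1 selenium; no ring) in place of a group of 4 heavy atoms (2 carbon, 1 nitrogen, 1 selenium; no ring), on a saturated chain carbon, four bonds along the chain from an oxygen next to a carbonyl group. Going by the values given here, no pair of measured compounds differing in just one place is available, so the size of such a step is not known from the data.

The change is small in count and the chain still ends in the same kind of group, so the step from compound 2 to compound 4 is expected to be a 1.2-fold lower number from compound 2 to compound 4 (0.07 log units; within the scatter), that is, within the usual scatter and with no clear direction. Compound 4 is therefore expected to give about 300 nM in this assay, within a range from 120 nM to 800 nM.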

Compound 4, half-maximal inhibitory concentration: 1020 nM
For compound 4 the middle estimate is 3.4-fold (0.53 log units) below the measured one, outside the stated range (above it).
By their numbers in this assay, from the lowest: compound 1; then compound 3; then compound 2; then compound 4.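

In this assay, shortening the chain at this position is not a neutral change: the group of 3 heavy atoms in place of the group of 4 heavy atoms gives a 2.9-fold higher number from compound 2 to compound 4 (0.46 log units; beyond the scatter), with the same selenocyanate end retained. Going by these compounds alone, this is the first one-place step available, and it shows that chain length alone, on a saturated chain carbon, four bonds along the chain from an oxygen next to a carbonyl group, can move the number beyond the scatter. No available measurement bears on why the number moves with this change.

As far as these compounds go, one step cannot define a trend along the chain, so whether a longer chain than that of compound 2 lowers the number remains open. Also open, from the compounds shown here alone, is whether an amine or a carboxylic acid at the chain end retains activity.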